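A few compounds are considered here, and "the series" means these few. Any claim that something is new, unique, unknown or untested is made for them only; others in the source may bear on it.

Measured so far in a functional assay on HepG2 cells (Homo sapiens) for antiproliferative activity, with a stated time of 72 h; a higher number here means that more compound is needed for the effect, a lower number that less compound is needed:
Compound 1 `COc1ccc(-c2c(Br)c(=O)c3c(OC)cc(OC)cc3n2S(=O)(=O)c2ccc(OC)cc2)cc1` gives only a limit, > 20000 nM.
Compound 2 `COC(=O)c1cc(=O)c2c(OC)cc(OC)cc2n1C` gives only a limit, > 19000 nM.
Compound 3 `COc1ccc(-c2cc(=O)c3c(OC)cc(OC)cc3n2S(=O)(=O)c2ccc(C)c([N+](=O)[O-])c2)cc1` gives only a limit, > 51700 nM.

Compound 3 thus stands at a limit of this assay, not at a measured number, (the limit of > 51700 nM in this assay, at which 1 of the 3 values shown sits). The other two compounds likewise sit at limits, the limit of > 19000 nM in this assay, at which 1 of the 3 values shown sits, and (the limit of > 20000 nM in this assay, at which 1 of the 3 values shown sits), so no compound shown here has a definite value.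

Compound 4 `COc1ccc(-c2cc(=O)c3c(OC)cc(OC)cc3n2S(=O)(=O)c2ccc(C)cc2)cc1` is the next candidate. The change from compound 3 is small: hydrogen in place of nitro on an aromatic carbon. Within the data shown here, with no measured step to lean on, the expected step in this assay, an at least 1.2-fold lower number from compound 3 to compound 4 (0.11 log units; that floor lies within the scatter), is none beyond the usual scatter. Compound 4 is therefore expected to give about 40000 nM, somewhere between 10000 nM and 200000 nM, most likely again reported only as a limit.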

Compound 4, half-maximal effective concentration: > 44800 nM
Compound 4: only a limit was reported; the forecaster's own chance of this, stated with the estimate: 75%; at least 1.1-fold (0.04 log units) between middle value and limit.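

Compound 3 and compound 4 both give only limits in this assay, so the step between them cannot be read. The compounds shown leave open whether hydrogen in place of nitro changes the effect, and what concentration any of them needs.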